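From 3-cyanopropyl to 2-cyanoethyl: one step, no measurement yet

The source may hold more compounds than are shown below. What is called first, only, known or untested is meant among the compounds shown, and "the series" means these compounds.

Compound 1 `COc1cc(OC)c2cc(-c3ccc(OCc4ccccc4)cc3)c(O)nc2c1` gives 10000 nM
Compound 2 `COc1ccc(-c2cc3c(OC)cc(OC)cc3n(CCCC#N)c2=O)cc1` gives 10000 nM

In a functional assay on T-24 cells (Homo sapiens) for cytotoxicity, read by colorimetric assay and MTT assay (a lower number here means a stronger inhibitor, a higher number a weaker inhibitor), compound 2 gives 10000 nM and so stands level with compound 1 at the digits shown, within the usual scatter. Compound 3 `COc1ccc(-c2cc3c(OC)cc(OC)cc3n(CCC#N)c2=O)cc1` has not yet been measured. It departs from compound 2 in one place, summed up as cyano in place of cyanomethyl on a saturated chain carbon, two bonds along the chain from an aromatic nitrogen with cyano in place of cyanomethyl on a saturated chain carbon, two bonds along the chain from an aromatic nitrogen. Cut one bond further out, the same difference reads 3-cyanopropyl to 2-cyanoethyl.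

Among the compounds with values here, no two measured compounds differ in just one place, so the data offer no direct guide to this change. In this assay the estimated step of no change at the digits printed from compound 2 to compound 3 (within the scatter) is expected to stay within the scatter, pointing in neither direction. That expectation rests only on compound 2 at 10000 nM as the closest measured relative. For compound 3 the expected value is 10000 nM with an estimated range from 4000 nM to 20000 nM across repeat measurements.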

Compound 3, half-maximal inhibitory concentration: 10000 nM
Estimate against measurement, compound 3: no gap at the digits printed; the range from low to high includes it.
By their numbers in this assay, from the lowest: compounds 1, 2 and 3 (each within the scatter of the next).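

Within the data shown here, this is the first step that can be read at a single place: in this assay, cyano in place of cyanomethyl on a saturated chain carbon, two bonds along the chain from an aromatic nitrogen, gives no change at the digits printed from compound 2 to compound 3 (within the scatter). Read by its other name, 3-cyanopropyl to 2-cyanoethyl, the change takes the heavy atoms of the leaving group from 3 to 2 while the nitrile stays in the group, and this one step leaves the printed value as it was. No measurement of any property of these compounds bears on this result.

A single pair at one level cannot show whether this position is able to move the value at all, or whether the chain length matters over a wider span than this one step. From the compounds shown here alone, whether a shorter cyanomethyl group, a longer chain such as 4-cyanobutyl, or an amine or a carboxylic acid in place of the nitrile would shift the number in this assay remains open.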